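A few compounds are considered here, and "the series" means these few. Any claim that something is new, unique, unknown or untested is made for them only; others in the source may bear on it.

Measured so far:
compound 1 `CC(=O)c1ccc(OCCCN2CCN(c3ncccn3)CC2)cc1O` — 15100 nM
compound 2 `CC(=O)c1ccc(OCCCN2CCCCC2)cc1O` — 2800 nM

In an assay on isolated protein for inhibition of Amine oxidase [flavin-containing] B (Homo sapiens), read by fluorescence, with a stated time of 30 min (on this read-out higher numbers stand for weaker inhibition and lower numbers for stronger inhibition), compound 2 gives 2800 nM, the lowest of the two numbers. Compound 1 gives 15100 nM, a higher number, and the gap between the two lies beyond the scatter. Compound 3 `CC(=O)c1ccc(OCCCN2CCCC2)cc1O` is not yet measured. It differs from compound 2 by pyrrolidin-1-yl in place of piperidin-1-yl on a saturated chain carbon, three bonds along the chain from an oxygen on an aromatic ring. For the measured compounds named here, no step between measured compounds covers a change of this kind, so the size of the effect in this assay is open; a small step is expected, toward weaker inhibition if any, and likely within the scatter. The estimate for compound 3 is 3500 nM, with a range of 1200 nM to 10000 nM. The step expected for compound 3 is a 1.3-fold higher number from compound 2 to compound 3 (0.10 log units; within the scatter).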

Compound 3, half-maximal inhibitory concentration: 620 nM
Beside the measured number, compound 3's estimate is 5.6-fold (0.75 log units) above it, outside the stated range (below it).
By their numbers in this assay, from the lowest: compound 3; then compound 2; then compound 1.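

In this assay, pyrrolidin-1-yl in place of piperidin-1-yl gives a 4.5-fold lower number from compound 2 to compound 3 (0.65 log units; beyond the scatter), so this position on the saturated chain carbon responds to ring size alone. The two groups differ by one ring carbon, while their counts of hydrogen-bond donors and acceptors and their net charge stay the same. No measurement here accounts for the step. Open, as far as these compounds go, is whether the trend extends to a still smaller azetidine ring or holds for an open-chain diethylamine. Also open, from the compounds shown here alone, is how morpholine or a longer chain would fare at this position.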